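Pyrazole for Chlorophenyl: Expected Efficacy of Compound 4

The compounds below may be only part of what the source reports. "The series", "measured", "known", "first", "only" and "open" are said of these compounds alone.

Of the compounds shown here, three sharing one core have so far been measured in an in vitro functional assay on HEK285-7 cells for antagonist activity at prostaglandin D2 receptor 2 (Homo sapiens), read by BRET and beta-arrestin recruitment; a lower number here means a smaller maximal response, a higher number a larger maximal response. Compound 1 `O=C(O)Cc1sc(C(c2ccccc2)c2ccc(Cl)cc2)nc1-c1ccc(F)cc1` gives 80%. Compound 2 `O=C(O)Cc1sc(C(c2ccc(F)cc2)c2ccc(F)cc2)nc1-c1ccc(Cl)cc1` gives 80% in this assay, and compound 3 `O=C(O)Cc1sc(C(c2ccccc2)c2ccc(F)cc2)nc1-c1ccc(Cl)cc1` gives 80%. Compound 2 thus stands level with compounds 1 and 3 at the digits given; its nearest neighbour is compound 1 and its furthest is compound 3, and both gaps lie within the scatter. Among the measured compounds shown here, the single step in which two measured compounds differ in one place, no change at the digits printed from compound 2 to compound 3 (within the scatter), consists of hydrogen in place of fluoro on an aromatic carbon.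

Compound 4 `O=C(O)Cc1sc(C(c2ccc(F)cc2)c2ccc(F)cc2)nc1-c1cn[nH]c1` has not yet been measured. It differs from compound 2 by 1H-pyrazol-4-yl in place of 4-chlorophenyl on an aromatic carbon. For the measured compounds named here, no measured step touches this kind of exchange: the only step available sits on a different ring, and it left this assay unchanged. The expectation for compound 4 therefore rests on compound 2 alone, whose value of 80% is taken as the anchor. The step of a number 5 percentage points lower from compound 2 to compound 4 (within the scatter) is expected to be small, with the range widened to allow for an untested exchange. Compound 4 is accordingly estimated at 75%, between 50% and 95%.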

Compound 4, largest response reached (reported as efficacy), in percent of the reference or control that the assay uses: 80%
Estimate against measurement, compound 4: 5 percentage points below; low and high end bracket the measured number.
By their numbers in this assay, from the lowest: compounds 1, 2, 3 and 4 (each within the scatter of the next).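

In this assay, the only exchange shown at this position, on the aromatic carbon next to the ring nitrogen, gives no change at the digits printed from compound 2 to compound 4 (within the scatter) when 1H-pyrazol-4-yl takes the place of 4-chlorophenyl. The earlier step, no change at the digits printed from compound 2 to compound 3 (within the scatter), lay on a different ring and said nothing about this site, whereas this pair shows that the maximal response can stay within the scatter when this aryl group is replaced. A six-membered aromatic ring of carbon only gives way here to a five-membered aromatic ring with 2 hetero atoms, bringing 1 hydrogen-bond donor and 1 hydrogen-bond acceptor, and the read-out does not separate the two compounds; no supporting evidence explains this result.

The compounds shown leave open whether a group of a different kind at this position, such as a methyl group, an amine or a piperidine ring, would also leave the maximal response within the scatter. They also leave open whether 1H-pyrazol-4-yl would behave the same way alongside the other substituents of compound 3, as this exchange is shown only on compound 2.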